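Methoxy Core Carrying the Isobutyl Amide Chain

The source may hold more compounds than are shown below. What is called first, only, known or untested is meant among the compounds shown, and "the series" means these compounds.

Measured so far in a functional assay on HeLa cells (Homo sapiens) for cytotoxicity, read by MTT assay, with a stated time of 24 h; on this read-out lower numbers stand for stronger inhibition and higher numbers for weaker inhibition:
Compound 1 `C=CC1=C(C(=O)NCCC)C(c2ccc(F)cc2)OC1`: > 100000 nM, a limit of the assay
Compound 2 `C=CC1=C(C(=O)NCC(C)C)C(c2ccc(F)cc2)OC1`: > 100000 nM, a limit of the assay
Compound 3 `C=CC1=C(C(=O)NCCC)C(c2ccc(OC)cc2)OC1`: 14000 nM

In this assay compound 1 gives > 100000 nM, which is a limit and not a number. Compound 2 likewise gives > 100000 nM, again a limit. Among the compounds with values here, compound 3 gives 14000 nM, the only number among the three; the other two sit at the limit of > 100000 nM in this assay, at which 2 of the 3 values shown sit.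

Compound 2 differs from compound 1 by methyl in place of hydrogen on a saturated chain carbon bound to two saturated chain carbons. The step that the two limits leave unreadable from compound 1 to compound 2 cannot be read because both values are limits. Compound 3 differs from compound 1 by methoxy in place of fluoro on an aromatic carbon, and here the step is an at least 7.1-fold lower number from compound 1 to compound 3 (0.85 log units; beyond the scatter).

Compound 4 `C=CC1=C(C(=O)NCC(C)C)C(c2ccc(OC)cc2)OC1` is not yet measured. It differs from compound 3 by methyl in place of hydrogen on a saturated chain carbon bound to two saturated chain carbons, the same change as from compound 1 to compound 2, at the same place. That earlier step gave no readable size, so the expectation rests on compound 3 and its value 14000 nM. As the change adds a single methyl, the step is expected to be small: compound 4 is expected at 14000 nM, between 5000 nM and 40000 nM, an expected step of no change at the digits printed from compound 3 to compound 4 (within the scatter) close to the scatter.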

Compound 4, half-maximal inhibitory concentration: > 100000 nM
Compound 4 ended at the assay's limit; the forecaster's own chance of this, stated with the estimate: 15%; middle value at least 7.1-fold (0.85 log units) away from the limit.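

In this assay, turning the propyl amide chain of compound 3 into an isobutyl chain gives an at least 7.1-fold higher number from compound 3 to compound 4 (0.85 log units; beyond the scatter), so on the core of compound 3 this single added methyl weakens inhibition by more than the scatter. Within the data shown here, the same change on the core of compound 1 cannot be read, and neither can the methoxy-for-fluoro step between compound 2 and compound 4, because both ends of each pair sit at a limit: the limit of > 100000 nM in this assay, at which 3 of the 4 values shown sit. Whether the change behaves alike on both cores therefore stays unproved, as only one core gives a readable step, and that step has a lower bound but no full size.

The compounds shown leave open how an ethyl or a butyl chain on the amide would compare with the propyl chain of compound 3 at 14000 nM. They also leave open how a chloro or a hydroxy group would read in place of the methoxy group.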